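Methyl addition on the aryl group of compound 2

A few compounds are considered here, and "the series" means these few. Any claim that something is new, unique, unknown or untested is made for them only; others in the source may bear on it.

compound 1 `CC(C)[C@@H](CO)n1cc(C(=O)O)c(=O)c2c(O)c(Cc3cccc(Cl)c3F)ccc21` gives 125000 nM
compound 2 `Cc1ccc(-n2cc(C(=O)O)c(=O)c3c(O)c(Cc4cccc(Cl)c4F)ccc32)cc1` gives 194000 nM

Both numbers come from an ADME assay on C8166 cells (Homo sapiens) for cytotoxicity, read by MTT assay (on this read-out lower numbers stand for higher toxicity in this test and higher numbers for lower toxicity in this test), and they are the only ones so far, so compound 2 stands within the scatter of compound 1. Compound 3 `Cc1ccc(-n2cc(C(=O)O)c(=O)c3c(O)c(Cc4cccc(Cl)c4F)ccc32)cc1C` differs from compound 2 in one place (methyl in place of hydrogen on an aromatic carbon) with methyl in place of hydrogen on an aromatic carbon, turning 4-methylphenyl into 3,4-dimethylphenyl. Among the compounds with values here, only one measured step bears on this, and it is indirect: a 1.6-fold higher number from compound 1 to compound 2 (0.19 log units; within the scatter) is a much larger exchange on the aromatic nitrogen, yet it stayed within the scatter. No step beyond the scatter is therefore expected for the smaller change. The expected step is a 1.1-fold lower number from compound 2 to compound 3 (0.06 log units; within the scatter) and no direction can be claimed for it. In this assay compound 3 is expected at 170000 nM with an estimated range of 90000 nM to 300000 nM on present data.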

Compound 3, half-maximal cytotoxic concentration: 316000 nM
The estimate for compound 3 lay 1.9-fold (0.27 log units) below the measured number; the whole stated range lies below it.
By their numbers in this assay, from the lowest: compounds 1, 2 and 3 (each within the scatter of the next, the first and the last beyond it).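

In this assay, methyl in place of hydrogen on an aromatic carbon, ortho to a methyl group and meta to a large group, gives a 1.6-fold higher number from compound 2 to compound 3 (0.21 log units; within the scatter) in this test, so this position takes the added methyl without a step beyond the scatter. Within the data shown here, the exchange on the aromatic nitrogen now reads as a 2.5-fold higher number from compound 1 to compound 3 (0.40 log units; beyond the scatter) and is the only one of the three steps to pass the scatter, though only modestly. Nothing measured here accounts for either step.

Going by these compounds, whether an amine or a methoxy group on this same aromatic carbon would stay within the scatter of compound 2 remains open. Also open, on these data alone, is how a longer chain on the aromatic nitrogen would read against compound 1 and compound 3.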